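Cyano in place of formyl on the sulfonyl aryl ring

The compounds below may be only part of what the source reports. "The series", "measured", "known", "first", "only" and "open" are said of these compounds alone.

Compound 3 `COc1ccc(-c2cc(=O)c3c(OC)cc(OC)cc3n2S(=O)(=O)c2ccc(C=O)cc2)cc1` has no number in a functional assay on SEM cells (Homo sapiens) for antiproliferative activity, with a stated time of 72 h; a higher number here means that more compound is needed for the effect, a lower number that less compound is needed: there compound 3 gives "not determined" (no result reported), and the same holds for compound 1 `COc1ccc(-c2c(Cl)c(=O)c3c(OC)cc(OC)cc3n2S(=O)(=O)c2ccc(OC)cc2)cc1`, for which compound 1 gives "not determined" (no result reported). Among the compounds with results, only compound 2 `COc1ccc(-c2c(I)c(=O)c3c(OC)cc(OC)cc3n2S(=O)(=O)c2ccc(OC)cc2)cc1` carries a value in this assay, where compound 2 gives 5520 nM. Compound 3 therefore stands nowhere on the numbers; nothing measured anchors it. Compound 4 `COc1ccc(-c2cc(=O)c3c(OC)cc(OC)cc3n2S(=O)(=O)c2ccc(C#N)cc2)cc1` differs from compound 3 in one place: cyano in place of formyl on an aromatic carbon. For the measured compounds named here, no measured pair shows this change, so its size in this assay cannot be read from the data; the step from compound 3 to compound 4 is expected to stay within the usual scatter, in no particular direction. Compound 2 at 5520 nM is the only reference point. Compound 4 is expected to give about 5000 nM in this assay, with a range from 1200 nM to 20000 nM.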

Compound 4, half-maximal effective concentration: 1300 nM
Estimate against measurement, compound 4: 3.8-fold (0.59 log units) above; measured number inside the range.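

No new step can be read from compound 4 and compound 3 in this assay. The compounds shown leave open how cyano compares with formyl on the sulfonyl aryl ring. No evidence given bears on this result.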